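Swapping methoxy for fluoro on a cytotoxicity scaffold

This account rests on a few compounds, and the source may have more. Where it says the series, first, only, none or still open, it means among the compounds named here.

Two compounds have been assessed so far in an ADME assay on RD cells (Homo sapiens) for cytotoxicity, read by MTT assay, with a stated time of 3 days; on this read-out higher numbers stand for lower toxicity in this test and lower numbers for higher toxicity in this test. Compound 1 `CCC[C@H](CCn1cncn1)c1ccc(F)cc1` gives 38.4 ug/mL. Compound 2 `CCCC[C@H](CCn1cncn1)c1ccc(OC)cc1` gives 28.3 ug/mL, which is the lowest of the two numbers, though the gap between compound 2 and compound 1 lies within the scatter of repeated measurements, so the two are not distinguished. Compound 3 `CCCC[C@H](CCn1cncn1)c1ccc(F)cc1` has not yet been measured in this assay. It differs from compound 2 in a single place: fluoro in place of methoxy on an aromatic carbon. Among the measured compounds shown here, no measured pair in this set carries this same change, so there is no directly comparable step to lean on; the account can only note that compound 1, which also carries fluoro at that position, gives 38.4 ug/mL. On that basis compound 3 is expected to sit near both measured compounds, and the step of a 1.2-fold higher number from compound 2 to compound 3 (0.07 log units; within the scatter) is estimated to stay within the scatter. The value of compound 3 is estimated at 33 ug/mL, with a range from 18 ug/mL to 60 ug/mL.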

Compound 3, half-maximal cytotoxic concentration: 35.2 ug/mL
The estimate for compound 3 lay 1.1-fold (0.03 log units) below the measured number; low and high end bracket the measured number.
By their numbers in this assay, from the lowest: compounds 2, 3 and 1 (each within the scatter of the next).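

In this assay the exchange of methoxy for fluoro on an aromatic carbon, para to a large group, now has a measured size: the data show a 1.2-fold higher number from compound 2 to compound 3 (0.09 log units; within the scatter) and thus no separable difference between these two groups at this position. Among the compounds shown here, compound 3 also provides the first single-place comparison on the chain. Methyl in place of hydrogen on a saturated chain carbon, four bonds along the chain from an aromatic carbon, gives a 1.1-fold lower number from compound 1 to compound 3 (0.04 log units; within the scatter) and again no separable difference.

As far as these compounds go, whether an amine or a carboxylic acid on that aromatic carbon, or a longer chain, would shift the number beyond the scatter remains open. The data offer no independent measurement that would help interpret either step.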